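The source may report more compounds than this note shows. Statements on the series, on what has been measured and on what is new or still open speak of the compounds shown alone.

Working notes on the stilbene series.

Compound 1 `COc1cc(/C=C/c2ccc(N(C)C)c([N+](=O)[O-])c2)cc(OC)c1OC` carries a nitro group and a dimethylamino group on one ring. In a functional assay on HeLa cells (Homo sapiens) for inhibition (on this read-out lower numbers stand for stronger inhibition and higher numbers for weaker inhibition), compound 1 gives > 5000 nM, which is a limit of the assay and not a number, as recorded in the limit of > 5000 nM in this assay, at which 1 of the 3 values shown sits. Compound 2 `COc1cc(/C=C/c2ccc(N(C)C)c(N)c2)cc(OC)c1OC` differs from compound 1 by amino in place of nitro on an aromatic carbon. In this assay compound 2 gives 1520 nM. The step of an at least 3.2-fold lower number from compound 1 to compound 2 (0.51 log units; beyond the scatter) is therefore known only as a floor, and the amino in place of nitro on an aromatic carbon reads as a gain of at least modest size.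

Compound 3 `COc1cc(/C=C/c2ccc3ccccc3c2)cc([N+](=O)[O-])c1OC` is built on a different core; the difference between the two cores is not broken down here. In this assay, within the data shown here, compound 3 gives 3200 nM, the higher of the two numbers measured so far, compound 2 standing nearer to it than compound 1.

Compound 4 `COc1cc(/C=C/c2ccc3ccccc3c2)cc(N)c1OC` is not yet measured. It differs from compound 3 by amino in place of nitro on an aromatic carbon. This is the same kind of change as that from compound 1 to compound 2, but the surroundings differ: in compound 1 the site is ortho to a dimethylamino group and meta to a large group, whereas in compound 3 it is ortho to a methoxy group, meta to a large group and meta to a methoxy group.

For compound 4 in this assay a step of a 2.7-fold lower number from compound 3 to compound 4 (0.43 log units; beyond the scatter) is expected, resting on the gain seen in an at least 3.2-fold lower number from compound 1 to compound 2 (0.51 log units; beyond the scatter) and on compound 3 giving 3200 nM. Compound 4 is estimated at 1200 nM, with a range of 500 nM to 3000 nM.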

Compound 4, half-maximal inhibitory concentration: 460 nM
Compound 4: the middle estimate sits 2.6-fold (0.42 log units) above what was measured; measured number below the stated range.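

In this assay, amino in place of nitro on an aromatic carbon goes with a lower number on both cores, and on the second core the step is a 7.0-fold lower number from compound 3 to compound 4 (0.84 log units; beyond the scatter). The direction of the change therefore carries over between these two cores, though this rests on two pairs only, whose sites also have different surroundings: the same change on two cores in this assay, an at least 3.2-fold lower number (0.51 log units; beyond the scatter) from compound 1 to compound 2 and a 7.0-fold lower number (0.84 log units; beyond the scatter) from compound 3 to compound 4; the limit leaves it open whether they differ

Compound 1 gives > 5000 nM, which is a limit of the assay and not a number, so the first step is known only as a floor, and nothing shown says whether the gain is larger on one core than on the other.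

The compounds shown leave open whether another group at this site, such as a hydroxyl, an acetamide or a methylamino group, would give a number as low as amino does on either core. They also leave open whether amino in place of nitro lowers the number on a third core, or on this second core when the methoxy group on the same ring gives way to an ethoxy group or a fluorine atom.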